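Swapping the Aryl Group on the Sulfonyl Sulfur

The source may report more compounds than this note shows. Statements on the series, on what has been measured and on what is new or still open speak of the compounds shown alone.

Of the compounds shown here, three built on one shared core have been measured in an assay on isolated protein for displacement of a labelled ligand from metabotropic glutamate receptor 5 (Homo sapiens), with a stated time of 60 min, tested at 1 uM; on this read-out lower numbers stand for less inhibition and higher numbers for more inhibition at the one concentration tested (going by the name of the read-out). Compound 1 `COc1ccc2ncc(S(=O)(=O)c3ccc(Cl)cc3)c(N3CCC(C)CC3)c2c1` gives 91%, compound 2 `COc1ccc2ncc(S(=O)(=O)c3ccc(Cl)c(Cl)c3)c(N3CCC(C)CC3)c2c1` gives 87%, and compound 3 `COc1ccc2ncc(S(=O)(=O)c3ccc(C)c(F)c3)c(N3CCC(C)CC3)c2c1` gives 73%, the lowest of the three numbers. The step of a number 18 percentage points lower from compound 1 to compound 3 (beyond the scatter) and the step of a number 14 percentage points lower from compound 2 to compound 3 (beyond the scatter) both came from changing the aryl group on the sulfonyl sulfur, and both were modest. Compound 4 `COc1ccc2ncc(S(=O)(=O)c3ccc(OC)c(OC)c3)c(N3CCC(C)CC3)c2c1` changes that same group once more: 3,4-dimethoxyphenyl in place of 3-fluoro-4-methylphenyl on a sulfonyl sulfur. The two earlier steps show that this position shifts the read-out by modest amounts, but neither involved methoxy groups, so the direction here is uncertain. A step of about a number 8 percentage points lower from compound 3 to compound 4 (within the scatter) is expected. Compound 4 is therefore estimated at 65%, within 45% to 85%.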

Compound 4, a percentage reported as inhibition, at one concentration (the size of the read-out at that concentration, not a potency): -3%
Estimate against measurement, compound 4: 68 percentage points above; the measured number lies below the stated range.
By their numbers in this assay, from the lowest: compound 4; then compound 3; then compounds 2 and 1 (each within the scatter of the next).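

At this position the choice of aryl group can decide almost everything, not just shift the number by modest amounts. With 3,4-dimethoxyphenyl on the sulfonyl sulfur, this assay shows a number 76 percentage points lower from compound 3 to compound 4 (beyond the scatter) and a number 90 percentage points lower from compound 2 to compound 4 (beyond the scatter) and a number 94 percentage points lower from compound 1 to compound 4 (beyond the scatter), so inhibition at the concentration tested is essentially gone. Nothing available explains this loss.

Whether a single methoxy group on the aryl ring is enough to cause it remains open. So does the outcome with an amine or a carboxylic acid on that ring.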